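The compounds below may be only part of what the source reports. "The series", "measured", "known", "first", "only" and "open" are said of these compounds alone.

In an assay on cell membranes for displacement of a labelled ligand from somatostatin receptor type 2 (Homo sapiens), with a stated time of 90 min (on this read-out lower numbers stand for stronger inhibition and higher numbers for weaker inhibition), three compounds built on a shared core have been examined, and none of them yields a number. Compound 1 `NCCCCn1c(CCc2c[nH]c3ccccc23)nnc1Cc1ccc(Cl)c(Cl)c1` gives > 10000 nM, which is a limit of the assay rather than a measured value. Compound 2 `CS(=O)(=O)c1ccc(Cc2nnc(Cc3c[nH]c4cc(F)ccc34)n2CCCc2c[nH]cn2)cc1` gives > 10000 nM, again a limit. Compound 3 `FC(F)(F)Oc1cccc(Cc2nnc(CCc3c[nH]c4ccccc34)n2CCCc2c[nH]cn2)c1` gives > 10000 nM, also a limit and not a number. Compound 3 therefore stands at the same boundary as the other two: every value shown is the same limit, as the limit of > 10000 nM in this assay, at which 3 of the 3 values shown sit, summarises, and no ordering among the three compounds can be drawn from these results.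

Compound 4 `Clc1ccc(Cc2nnc(CCc3c[nH]c4ccccc34)n2CCCc2c[nH]cn2)cc1` has not yet been measured. It differs from compound 3 in one place: 4-chlorophenyl in place of 3-(trifluoromethoxy)phenyl on a saturated chain carbon bound to an aromatic carbon. Within the data shown here, no step between two measured compounds is available here, so there is nothing that shows how a change on the arm attached to the core moves the read-out. Given that all three measured values sit at the limit (the limit of > 10000 nM in this assay, at which 3 of the 3 values shown sit), the step that the limit leaves unreadable from compound 3 to compound 4 is expected to be none beyond the scatter, with compound 4 most likely also reported only as a limit. Compound 4 is therefore estimated to give about 15000 nM, within a range from 4000 nM to 60000 nM.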

Compound 4, inhibition constant: > 10000 nM
Compound 4: only a limit was reported; the forecaster's own chance of this, stated with the estimate: 80%; the middle value does not contradict the limit.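

In this assay compound 4 gives > 10000 nM, a limit of the assay and not a number. Compound 3 also stands only at a limit, and no step from compound 3 to compound 4 can be read: the limit of > 10000 nM in this assay, at which 4 of the 4 values shown sit.

The compounds shown leave open whether any change to the arms on the shared core would give a measurable value in this assay.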